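A few compounds are considered here, and "the series" means these few. Any claim that something is new, unique, unknown or untested is made for them only; others in the source may bear on it.

Measured compounds in this series:
- compound 1 `COc1cc2c(Oc3ccc(NC(=O)c4cn(-c5ccccc5)nn4)cc3F)ccnc2cc1OCCCN1CCCC1`, 260 nM
- compound 2 `COc1cc2c(Oc3ccc(NC(=O)c4cn(-c5ccc(Br)cc5)nn4)cc3F)ccnc2cc1OCCCN1CCCC1`, 120 nM
- compound 3 `COc1cc2c(Oc3ccc(NC(=O)c4cn(-c5c(C)cccc5C)nn4)cc3F)ccnc2cc1OCCCN1CCCC1`, 3490 nM

All three were run in a functional assay on MKN-45 cells (Homo sapiens) for cytotoxicity, read by MTT assay, with a stated time of 72 h; on this read-out lower numbers stand for stronger inhibition and higher numbers for weaker inhibition. Compound 1 sits second highest of the three numbers: the move to compound 2 is a 2.2-fold lower number from compound 1 to compound 2 (0.34 log units; beyond the scatter), while the move to compound 3 is a 13-fold higher number from compound 1 to compound 3 (1.13 log units; beyond the scatter), and the gap between compounds 2 and 3 is a 29-fold higher number from compound 2 to compound 3 (1.46 log units; beyond the scatter). Both of those changes sit on the aryl group attached to the aromatic nitrogen.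

Compound 4 `COc1cc2c(Oc3ccc(NC(=O)c4cn(-c5ccccc5)nn4)cc3F)ccnc2cc1OCCCN1CCN(C)CC1` leaves that part untouched and instead alters the basic tail: 4-methylpiperazin-1-yl in place of pyrrolidin-1-yl on a saturated chain carbon, three bonds along the chain from an oxygen on an aromatic ring. Among the compounds with values here, no measured step touches this chain amine, so the measured steps offer no direct guide; they only show that this assay responds strongly to changes elsewhere in the molecule. With no comparator for the tail, the expected step of a 1.2-fold higher number from compound 1 to compound 4 (0.06 log units; within the scatter) from compound 1 to compound 4 is small, plausibly within the scatter, in either direction. Compound 4 is therefore estimated at 300 nM, with a range of 120 nM to 750 nM.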

Compound 4, half-maximal inhibitory concentration: 60 nM
For compound 4 the middle estimate is 5.0-fold (0.70 log units) above the measured one; measured number below the stated range.
By their numbers in this assay, from the lowest: compounds 4 and 2 (each within the scatter of the next); then compound 1; then compound 3.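

Moving from 3-(pyrrolidin-1-yl)propyl to 3-(4-methylpiperazin-1-yl)propyl gives in this assay a 4.3-fold lower number from compound 1 to compound 4 (0.64 log units; beyond the scatter), so the chain amine is a working point of variation in this read-out, not only the aryl group on the aromatic nitrogen. The step combines several differences: a six-membered ring in place of a five-membered one, a second ring nitrogen and an added methyl, and this single pair cannot separate them. Nothing available explains why the number falls with this change.

Piperidin-1-yl and morpholin-4-yl on the same chain would help show which of those differences carries the step. Also open, as far as these compounds go, is whether 4-methylpiperazin-1-yl gives a similar step when the aromatic nitrogen carries 4-bromophenyl instead of phenyl.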